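Hydroxyl moved onto the piperidine ring of compound 3

A few compounds are considered here, and "the series" means these few. Any claim that something is new, unique, unknown or untested is made for them only; others in the source may bear on it.

Three compounds sharing one core have been examined in an assay on HEK293 cells for displacement of a labelled ligand from NPC1-like intracellular cholesterol transporter 1 (Homo sapiens); a higher number here means a weaker inhibitor, a lower number a stronger inhibitor. Compound 1 `CC(C)(C)OC(=O)NC1CCN(C(=O)CN2CN(c3ccccc3)C3(CCN(C(=O)c4ccc(C(C)(C)C)cc4)CC3)C2=O)CC1` gives 8300 nM in this assay, compound 2 `CC1CCCN(C(=O)CN2CN(c3ccccc3)C3(CCN(C(=O)c4ccc(C(C)(C)C)cc4)CC3)C2=O)C1` gives 12000 nM, and compound 3 `CC(C)(C)c1ccc(C(=O)N2CCC3(CC2)C(=O)N(CC(=O)N2CCCC(CO)C2)CN3c2ccccc2)cc1` gives 8200 nM. Compound 3 carries the lowest of the three numbers, yet neither compound 1 nor compound 2 is separated from it beyond the scatter, so the three sit together on this scale. Among the compounds with values here, the single one-place step measured so far, a 1.5-fold lower number from compound 2 to compound 3 (0.17 log units; within the scatter), comes from adding a hydroxy group to the piperidine side chain and stays within the scatter.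

Compound 4 `CC(C)(C)c1ccc(C(=O)N2CCC3(CC2)C(=O)N(CC(=O)N2CCC(O)CC2)CN3c2ccccc2)cc1` has not yet been measured. It differs from compound 3 by 4-hydroxypiperidin-1-yl in place of 3-(hydroxymethyl)piperidin-1-yl on a carbonyl carbon. The change keeps the hydrogen-bond donor and acceptor count of the piperidine unit and removes one carbon. Within the data shown here, the only step that bears on it is the one from compound 2 to compound 3, which showed that placing a hydroxy group on this piperidine hardly altered the number, so no step beyond the scatter is expected in this assay for compound 4, in either direction. Compound 4 is therefore estimated to give 8500 nM, with a range from 4000 nM to 18000 nM, which corresponds to an expected step of a 1.0-fold higher number from compound 3 to compound 4 (0.02 log units; within the scatter).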

Compound 4, half-maximal inhibitory concentration: 4700 nM
Compound 4: middle estimate off by 1.8-fold (0.26 log units), on the high side; the measured number falls inside the stated range.
By their numbers in this assay, from the lowest: compounds 4, 3, 1 and 2 (each within the scatter of the next, the first and the last beyond it).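

In this assay, 4-hydroxypiperidin-1-yl in place of 3-(hydroxymethyl)piperidin-1-yl on the carbonyl carbon gives a 1.7-fold lower number from compound 3 to compound 4 (0.24 log units; within the scatter) and so leaves compound 4 unseparated from compound 3, which shows that this position accepts a hydroxy group set directly on the piperidine ring as well as one carried on a hydroxymethyl chain. Set against the 3-methylpiperidin-1-yl group, the same 4-hydroxypiperidin-1-yl group gives a 2.6-fold lower number from compound 2 to compound 4 (0.41 log units; beyond the scatter) and provides the first modest step beyond the scatter among these compounds, whereas hydroxy in place of (tert-butoxycarbonyl)amino on the saturated ring carbon gives a 1.8-fold lower number from compound 1 to compound 4 (0.25 log units; within the scatter) and stays within it. That modest step changes both the group and its ring position at once, and no measurement in hand accounts for it.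

The compounds shown leave open whether the hydroxy group or its ring position matters more, a question that 4-methylpiperidin-1-yl, 3-hydroxypiperidin-1-yl or the plain piperidin-1-yl group could separate. They also leave open how this position would respond to a 4-amino group, a 4-carboxylic acid or a 4-methoxy group on the same ring.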